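The source may hold more compounds than are shown below. What is called first, only, known or untested is meant among the compounds shown, and "the series" means these compounds.

Of the compounds shown here, three have been measured in a functional assay on LNCaP cells (Homo sapiens) for cytotoxicity; on this read-out higher numbers stand for weaker inhibition and lower numbers for stronger inhibition. Compound 1 `CNC(=O)Nc1ccc(-c2nc(N3CC4CCC(C3)O4)c3cnn(C(C)C)c3n2)cc1` gives 5 nM. Compound 3 `CNC(=O)Nc1ccc(-c2nc(N3CC4CCC(C3)O4)c3cnn(CCO)c3n2)cc1`, with 2-hydroxyethyl in place of isopropyl on an aromatic nitrogen, gives 650 nM, and that change amounts to a 130-fold higher number from compound 1 to compound 3 (2.11 log units; beyond the scatter). Compound 2 `O=C(Nc1ccccc1)Nc1ccc(-c2nc(N3CC4CCC(C3)O4)c3cnn(C4CCC5(CC4)OCCO5)c3n2)cc1` gives 4 nM, which lies within the scatter of the value of compound 1 and far from the value of compound 3.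

Compound 4 `CCNC(=O)Nc1ccc(-c2nc(N3CC4CCC(C3)O4)c3cnn(C4CCC5(CC4)OCCO5)c3n2)cc1` has not yet been measured. Compared with compound 2, it has ethyl in place of phenyl on an amide-type nitrogen. For the measured compounds named here, no measured step changes this group alone. The large step to compound 3 concerns a different place in the molecule, so its size cannot be carried over. The nearest evidence is indirect: compound 1, with methyl rather than phenyl on that nitrogen and a different group on the aromatic nitrogen, gives 5 nM, within the scatter of the value of compound 2. No step beyond the scatter is therefore expected in this assay, although the evidence is thin. The expected change is a 1.5-fold higher number from compound 2 to compound 4 (0.18 log units; within the scatter). Compound 4 is estimated at 6 nM, with an expected range from 2 nM to 30 nM.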

Compound 4, half-maximal inhibitory concentration: 1 nM
For compound 4 the middle estimate is 6.0-fold (0.78 log units) above the measured one; the whole stated range lies above it.
By their numbers in this assay, from the lowest: compound 4; then compounds 2 and 1 (each within the scatter of the next); then compound 3.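

The group on the amide-type nitrogen had not been isolated by any earlier step, and this pair shows that it can shift the number in this assay, as ethyl in place of phenyl gives a 4.0-fold lower number from compound 2 to compound 4 (0.60 log units; beyond the scatter). The change replaces 6 heavy atoms and a six-membered aromatic ring of carbon only with 2 heavy atoms and no ring, so for this pair, with everything else held the same, the aromatic ring on this nitrogen is not needed for a low number, and the smaller group gives the lower one. Nothing available here accounts for this step.

Compound 1 carries methyl on that nitrogen but also differs from compound 4 on the aromatic nitrogen, so it cannot show whether the step to ethyl would hold with isopropyl there or how methyl compares with ethyl on its own. As far as these compounds go, it also remains open how a longer chain such as n-propyl, or a chain ending in an amine or a carboxylic acid, would read on this nitrogen with the rest of compound 4 kept unchanged.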